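The source may report more compounds than this note shows. Statements on the series, on what has been measured and on what is new or still open speak of the compounds shown alone.

Measured compounds:
compound 1, `O=C(Nc1cc(C(F)(F)F)cc(C(F)(F)F)c1)C1CCc2ccccc2N1C(=O)c1cccc(Cl)c1` — 813 nM
compound 2, `O=C(Nc1ccc(C(F)(F)F)cc1)C1CCc2ccccc2N1` — 25000 nM

Compound 1 holds the lower of the two numbers in a functional assay on ACHN cells (Homo sapiens) for cytotoxicity, read by sulforhodamine B assay, with a stated time of 72 h; on this read-out lower numbers stand for stronger inhibition of growth and higher numbers for weaker inhibition of growth. Compound 2 gives 25000 nM, a number well beyond the scatter above that of compound 1, so the two stand clearly apart; no single-point difference between them is worked out here, and nothing more is read from the pair.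

The next compound is compound 3, `CCCCCCCCC(=O)N1c2ccccc2CCC1C(=O)Nc1cc(C(F)(F)F)cc(C(F)(F)F)c1`. Compared with compound 1 the change is octyl in place of 3-chlorophenyl on a carbonyl carbon. The ring amide remains acylated; only the acyl group changes, an octylcarbonyl in place of the (3-chlorophenyl)carbonyl. For the measured compounds named here, no measured pair shows this kind of exchange, so the size of the step rests on judgement alone. The expectation is a modest loss in this assay, possibly within the scatter, rather than a change of the order separating compound 1 from compound 2. Compound 3 is estimated at 2000 nM, range 600 nM to 8000 nM, which means an expected step of a 2.5-fold higher number from compound 1 to compound 3 (0.39 log units; beyond the scatter).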

Compound 3, concentration for 50% growth inhibition: 4520 nM
Beside the measured number, compound 3's estimate is 2.3-fold (0.35 log units) below it; the measured number falls inside the stated range.
By their numbers in this assay, from the lowest: compound 1; then compound 3; then compound 2.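

In this assay, octyl in place of 3-chlorophenyl on a carbonyl carbon comes with a 5.6-fold higher number from compound 1 to compound 3 (0.75 log units; beyond the scatter) and so shows that this acyl position is not indifferent to the group it carries. The exchange removes the aromatic ring and the chlorine together, yet compound 3 still gives a finite number of 4520 nM in this assay, so a ring at this place is not needed for a measurable reading in this assay. Nothing available here accounts for the size of this step or assigns it to the lost ring, the lost chlorine or the entering chain.

For the compounds shown here, the single exchange cannot separate the contribution of the chlorine from that of the ring, and a plain phenyl on the same carbonyl would be the direct test of that point. From the compounds shown here alone, how the number depends on chain length also remains open, as does the effect of a shorter chain such as butyl, a longer chain such as dodecyl, or a chain carrying an amine or a carboxylic acid.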